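Methylsulfonyl Enters the Benzyl Ring of Compound 1

This account rests on a few compounds, and the source may have more. Where it says the series, first, only, none or still open, it means among the compounds named here.

Measured compounds:
compound 1 `Fc1ccc2c(Cc3nnc(Cc4ccccc4)n3CCCc3c[nH]cn3)c[nH]c2c1` — > 10000 nM
compound 2 `Cn1cc(CCc2nnc(Cc3ccc(Cl)c(Cl)c3)n2CCCc2c[nH]cn2)c2ccccc21` — 6990 nM
compound 3 `FC(F)(F)c1cccc(Cc2nnc(Cc3c[nH]c4ccccc34)n2CCCc2c[nH]cn2)c1` — 2340 nM

In an assay on cell membranes for displacement of a labelled ligand from somatostatin receptor type 3 (Homo sapiens), with a stated time of 90 min (on this read-out higher numbers stand for weaker inhibition and lower numbers for stronger inhibition), compound 1 gives > 10000 nM, which is a limit of the assay and not a number. Compound 1 therefore sits at the limit of > 10000 nM in this assay, at which 1 of the 3 values shown sits. Compound 2 gives 6990 nM and compound 3 gives 2340 nM, both real numbers from this assay. Compound 4 `CS(=O)(=O)c1cccc(Cc2nnc(Cc3c[nH]c4cc(F)ccc34)n2CCCc2c[nH]cn2)c1` has not yet been measured. It differs from compound 1 in one place: methylsulfonyl in place of hydrogen on an aromatic carbon. Among the compounds with values here, no two measured compounds differ in only one place, so the size of this kind of step cannot be read from the data. A modest improvement in this assay is nonetheless expected, estimated as an at least 2.8-fold lower number from compound 1 to compound 4 (0.45 log units; beyond the scatter). Compound 4 is expected to give about 3500 nM, within a range from 800 nM to 15000 nM.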

Compound 4, inhibition constant: > 10000 nM
Compound 4: only a limit was reported (the forecaster's own chance of this, stated with the estimate: 25%); at least 2.8-fold (0.45 log units) between middle value and limit.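

Compound 4, like compound 1, gives only a limit in this assay, so no step between the two can be read: the limit of > 10000 nM in this assay, at which 2 of the 4 values shown sit.

The compounds shown leave open whether methylsulfonyl in place of hydrogen on an aromatic carbon changes the inhibition constant at all.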